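Inverting the ring stereocentre of compound 2

The compounds below may be only part of what the source reports. "The series", "measured", "known", "first", "only" and "open" are said of these compounds alone.

Among the measured compounds shown here, in a functional assay on A2780 ADR cells (Homo sapiens) for cytotoxicity, read by MTT assay, with a stated time of 24 h (on this read-out lower numbers stand for stronger inhibition and higher numbers for weaker inhibition), compound 2 (`CCCCC[C@@H](CCC[C@@H]1CC=CC(=O)O1)OC`) gives 11500 nM and holds the lower of the two numbers so far. Compound 1 (`CCCCC[C@@H](C[C@@H](O)C[C@@H]1CC=CC(=O)O1)OC`) gives 46300 nM in this assay. For the measured compounds named here, the only measured step, a 4.0-fold lower number from compound 1 to compound 2 (0.60 log units; beyond the scatter), concerns hydrogen in place of hydroxy on a saturated chain carbon, so it bears only indirectly on configuration. Compound 3 (`CCCCC[C@@H](CCC[C@H]1CC=CC(=O)O1)OC`) changes one thing (the two compounds have the same atoms and bonds and differ only in configuration as drawn: 1 of 2 stereo elements differ; a stereocentre at a saturated ring carbon is drawn R in compound 2 and S in compound 3). Going by the values given here, no measured step tests this inversion, so no shift beyond the scatter is expected in this assay. The estimate means a 1.2-fold higher number from compound 2 to compound 3 (0.09 log units; within the scatter) as the expected step. For compound 3 the estimated value is 14000 nM (range 5000 nM to 40000 nM).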

Compound 3, half-maximal inhibitory concentration: 9000 nM
Compound 3: middle estimate off by 1.6-fold (0.19 log units), on the high side, within the range that was stated.
By their numbers in this assay, from the lowest: compounds 3 and 2 (each within the scatter of the next); then compound 1.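

In this assay, inverting the stereocentre at the saturated ring carbon gives a 1.3-fold lower number from compound 2 to compound 3 (0.11 log units; within the scatter), so the R and S drawings at this position are not separated by this read-out. This step isolates configuration at that carbon, which the hydroxy-to-hydrogen step did not test: the fact that compounds 2 and 3 differ only in the configuration as drawn. The compounds shown leave open whether the inversion behaves alike with the hydroxy group of compound 1 present, and what the other stereocentre contributes. Also open, on these data alone, is whether an amine on the chain, or a longer chain, would shift the number beyond the scatter.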